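The source may report more compounds than this note shows. Statements on the series, on what has been measured and on what is new or still open speak of the compounds shown alone.

Series notes. Compound 1 `C=CCOc1c(C)c(C)c2c(c1C)CCC(C)(COc1ccc(/C=C3\SC(=O)NC3=O)cc1OC)O2` in a functional assay on MCF7 cells (Homo sapiens), tested at 2.5 uM (a higher number here means a weaker effect of the compound at the concentration tested, a lower number a stronger effect), gives 34%. Among the compounds with values here, compound 2 `CC(C)=CCOc1c(C)c(C)c2c(c1C)CCC(C)(COc1ccc(/C=C3\SC(=O)NC3=O)cc1F)O2` in this assay gives 95%, the higher of the two numbers; the number for compound 1 lies well beyond the scatter of it, but as the two compounds differ in more than one place no single step is read from them. Compound 3 `CC(C)=CCOc1c(C)c(C)c2c(c1C)CCC(C)(COc1ccc(/C=C3\SC(=O)NC3=O)cc1C)O2` carries methyl in place of fluoro on an aromatic carbon. Within the data shown here, no measured pair isolates this change. The step of a number 15 percentage points lower from compound 2 to compound 3 (beyond the scatter) is expected to be small, downward if anything, and may not exceed the scatter. Compound 3 is expected to give 80%, within 45% to 100%.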

Compound 3, a percentage reported as activity, at one concentration (the size of the read-out at that concentration, not a potency): 89%
Compound 3: the middle estimate sits 9 percentage points below what was measured, within the range that was stated.
By their numbers in this assay, from the lowest: compound 1; then compounds 3 and 2 (each within the scatter of the next).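

In this assay, within the data shown here, methyl in place of fluoro on this aromatic carbon, ortho to a large group, gives a number 6 percentage points lower from compound 2 to compound 3 (within the scatter), the first step that isolates a single change. At this position, the two groups are therefore not separated by this read-out at the concentration tested. Among these compounds, no evidence on these compounds bears on this result.

Compound 1 differs from compound 2 and compound 3 in more than one place, so steps involving it cannot be read. From the compounds shown here alone, whether an amine or a carboxylic acid on this aromatic carbon would shift the number remains open.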